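The source may report more compounds than this note shows. Statements on the series, on what has been measured and on what is new or still open speak of the compounds shown alone.

Working notes on a small set of chalcone-type pyrazoles tested for cytotoxicity at a single concentration.

Compound 1, `COc1cc(-c2cc(/C=C/C(=O)c3ccc(N)cc3)[nH]n2)cc(OC)c1OC`, and compound 2, `COc1ccc(-c2cc(/C=C/C(=O)c3ccc(N)cc3)[nH]n2)cc1OC`, share one core and differ in a single place; the difference is hydrogen in place of methoxy on an aromatic carbon. In a functional assay on Malme-3M cells (Homo sapiens) for cytotoxicity, read by sulforhodamine B assay, with a stated time of 48 h, tested at 0.1 uM (on this read-out lower numbers stand for a stronger effect and higher numbers for a weaker effect at the one concentration tested), compound 1 gives 102%, and in the same assay compound 2 gives 108%. Going by the values given here, the step between them is a number 6 percentage points higher from compound 1 to compound 2 (within the scatter), so the cells show essentially no response to either compound at the concentration tested.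

Compound 3, `COc1cc(C(=O)/C=C/c2cc(-c3cc(OC)c(OC)c(OC)c3)n[nH]2)cc(OC)c1OC`, rests on a different core; how the core of compound 3 differs from the core of compound 1 is not broken down here. In this assay compound 3 gives 101%, a number indistinguishable from those of compound 1 and compound 2 within the usual scatter.

Compound 4, `COc1ccc(-c2cc(/C=C/C(=O)c3cc(OC)c(OC)c(OC)c3)[nH]n2)cc1OC`, is not yet measured. It differs from compound 3 by hydrogen in place of methoxy on an aromatic carbon, which is the same change already made from compound 1 to compound 2, with the same surroundings around the place. That earlier step, a number 6 percentage points higher from compound 1 to compound 2 (within the scatter), produced no movement beyond the scatter, and the starting value of compound 3 is 101%. The expected step from compound 3 to compound 4 is therefore a number 3 percentage points higher from compound 3 to compound 4 (within the scatter), a step estimated to lie within the scatter, because the earlier a number 6 percentage points higher from compound 1 to compound 2 (within the scatter) did. Compound 4 is expected to give 104% in this assay, with an estimated range from 92% to 116%.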

Compound 4, a percentage reported as activity, at one concentration (the size of the read-out at that concentration, not a potency): 89%
For compound 4 the middle estimate is 15 percentage points above the measured one; measured number below the stated range.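

In this assay the replacement of methoxy by hydrogen does not transfer as a fixed increment between these two cores: the same change on two cores in this assay, a number 6 percentage points higher (within the scatter) from compound 1 to compound 2 and a number 12 percentage points lower (beyond the scatter) from compound 3 to compound 4, 18 percentage points apart, beyond the scatter of two such steps

On the core of compound 3, the change gives a number 12 percentage points lower from compound 3 to compound 4 (beyond the scatter), whereas the same change on the core of compound 1 gives a number 6 percentage points higher from compound 1 to compound 2 (within the scatter), so a step read on one core cannot be assumed to hold on the other in this series. Going by these compounds alone, this does not show which feature of the two cores separates the steps, nor whether the gap would persist at another concentration, and with only two pairs it gives no general rule for the change across the series.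

The compounds shown have only methoxy or hydrogen at the place of change, so it remains open whether a hydroxy group, a chlorine atom or a carboxylic acid there would follow the step seen on either core. Also open, on these data alone, is whether removing a further methoxy group from the same ring of compound 4 would extend the step seen on this core or leave the read-out where it stands.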